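Hydroxyl for ketone on the side chain of compound 2

A few compounds are considered here, and "the series" means these few. Any claim that something is new, unique, unknown or untested is made for them only; others in the source may bear on it.

Two compounds with a shared core were measured in an assay on HL-60 cells for agonist activity at vitamin D3 receptor (Homo sapiens), read by microscopy, with a stated time of 96 h; on this read-out higher numbers stand for an effect only at larger amounts of compound and lower numbers for an effect already at smaller amounts. Compound 1 `CCN(CC)CCCNC(=O)c1ccc(C(CC)(CC)c2ccc(OCC(O)C(C)(C)C)c(C)c2)n1CC` gives 66 nM. Compound 2 `CCn1c(C(=O)OCc2ccc(F)cc2)ccc1C(CC)(CC)c1ccc(OCC(=O)C(C)(C)C)c(C)c1` gives 9500 nM, the higher of the two numbers; the gap to compound 1 lies beyond the usual scatter of repeated measurements. Among the compounds with values here, no single-point step between the two measured compounds is available, as they differ in more than one place.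

Compound 3 `CCn1c(C(=O)OCc2ccc(F)cc2)ccc1C(CC)(CC)c1ccc(OCC(O)C(C)(C)C)c(C)c1` has not yet been measured. It departs from compound 2 in one place: 1-hydroxy-2,2-dimethylpropyl in place of (tert-butyl)carbonyl on a saturated chain carbon bound to an oxygen on an aromatic ring. Compound 3 thereby carries the same 2-hydroxy-3,3-dimethylbutoxy chain that is found in compound 1, while keeping the ester of compound 2.

A step from compound 2 to compound 3 toward a lower number, beyond the scatter, is expected, of the size a 16-fold lower number from compound 2 to compound 3 (1.20 log units; beyond the scatter), since compound 1 with that hydroxyl chain gives 66 nM. In this assay compound 3 is estimated to give 600 nM, with a plausible range from 100 nM to 4000 nM.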

Compound 3, half-maximal effective concentration: > 50000 nM
Compound 3: a limit, no number; the forecaster's own chance of this, stated with the estimate: 5%; middle value at least 83-fold (1.92 log units) away from the limit.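

Compound 3 gives no number in this assay, only a limit: the limit of > 50000 nM in this assay, at which 1 of the 3 values shown sits.

On the ester of compound 2, putting 1-hydroxy-2,2-dimethylpropyl in place of (tert-butyl)carbonyl on a saturated chain carbon bound to an oxygen on an aromatic ring gives an at least 5.2-fold higher number from compound 2 to compound 3 (0.72 log units; beyond the scatter), so this change does not bring a lower number here, and the 2-hydroxy-3,3-dimethylbutoxy chain alone does not account for the low number of compound 1. With that chain held the same, (4-fluorobenzyl)oxy in place of (3-(diethylamino)propyl)amino on a carbonyl carbon gives an at least 750-fold higher number from compound 1 to compound 3 (2.87 log units; beyond the scatter), a large step that ties the low number of compound 1 to the group on the carbonyl carbon.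

Going by these compounds, what the (tert-butyl)carbonyl chain would give together with the (3-(diethylamino)propyl)amino group stays open, so the change of this step can be read only on the ester. Also open, on these data alone, is how far a carboxylic acid, or a shorter amine such as a (2-(diethylamino)ethyl)amino group, on that carbonyl carbon would carry the number of the hydroxyl compounds.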